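Furan-2-yl to Furan-3-yl on a Carbonyl Carbon

The compounds below may be only part of what the source reports. "The series", "measured", "known", "first", "only" and "open" are said of these compounds alone.

In a functional assay on SF-539 cells (Homo sapiens) for inhibition, read by colorimetric assay and sulforhodamine B assay, with a stated time of 48 h (a higher number here means a weaker inhibitor of growth, a lower number a stronger inhibitor of growth), compound 1 (`CCCCCCCCCCCC[C@@H](O)[C@H]1CC[C@H]([C@H](O)CCCCCCCCCCNC(=O)c2cccs2)O1`) gives 17000 nM, and compound 2 (`CCCCCCCCCCCC[C@@H](O)[C@H]1CC[C@H]([C@H](O)CCCCCCCCCCNC(=O)c2ccco2)O1`) gives 81300 nM. Compound 2 therefore holds the higher of the two values and is the weaker growth inhibitor of the pair. Compound 3 (`CCCCCCCCCCCC[C@@H](O)[C@H]1CC[C@H]([C@H](O)CCCCCCCCCCNC(=O)c2ccoc2)O1`) keeps the shared core and has furan-3-yl in place of furan-2-yl on a carbonyl carbon. Among the measured compounds shown here, only one measured step bears on this change, the replacement of thiophen-2-yl by furan-2-yl at the same place, a 4.8-fold higher number from compound 1 to compound 2 (0.68 log units; beyond the scatter), which is modest but beyond the scatter. That step swapped one ring for another, whereas compound 3 has the same atoms as compound 2, joined differently. For the measured compounds named here, it shows only that the group on this carbonyl carbon can shift the number, and no furan-3-yl compound has yet been measured. Going by the values given here, compound 2 sits at 81300 nM, the high end of the values so far, so a modest move to a lower number is expected, though the direction is tentative. The expected change is a 2.3-fold lower number from compound 2 to compound 3 (0.37 log units; beyond the scatter). For compound 3 the estimated value is 35000 nM, with an expected range of 12000 nM to 100000 nM.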

Compound 3, concentration for 50% growth inhibition: 100000 nM
Estimate against measurement, compound 3: 2.9-fold (0.46 log units) below; low and high end bracket the measured number.
By their numbers in this assay, from the lowest: compound 1; then compounds 2 and 3 (each within the scatter of the next).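

In this assay, changing only where the furan ring is joined to the carbonyl carbon gives a result within the scatter (a 1.2-fold higher number from compound 2 to compound 3 (0.09 log units; within the scatter)), so this assay does not separate furan-2-yl from furan-3-yl at this position. The gap to the thiophene holds for the new furan as well (a 5.9-fold higher number from compound 1 to compound 3 (0.77 log units; beyond the scatter)), which makes compound 1, with thiophen-2-yl, the strongest growth inhibitor of the three, since its steps to both furan compounds are beyond the scatter. Nothing available offers an explanation for these numbers.

The compounds leave open whether a thiophen-3-yl or phenyl group on the same carbonyl carbon would stay close to compound 1 or fall in with compound 2 and compound 3, and so whether the thiophen-2-yl result is particular to that one ring. Also open, on these data alone, is whether a methyl group on the furan ring, or a shorter chain leading to the amide nitrogen, would change the number at all.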